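This account rests on a few compounds, and the source may have more. Where it says the series, first, only, none or still open, it means among the compounds named here.

Working notes on the series.

Compound 1 `CCCCCCCCCCCCCCNC(=O)[C@@H](NC(=O)c1cc2ccccc2o1)[C@@H](C)O` gives 20100 nM in a functional assay on A-431 cells (Homo sapiens) for cytotoxicity, read by MTT assay, with a stated time of 48 h; on this read-out lower numbers stand for stronger inhibition and higher numbers for weaker inhibition. Compound 2 `CCCCCCCCCCCCCCNC(=O)[C@@H](NC(=O)c1nccc2ccccc12)[C@@H](C)O` differs from compound 1 by isoquinolin-1-yl in place of 1-benzofuran-2-yl on a carbonyl carbon. In this assay compound 2 gives 23000 nM, so that the two values sit within the scatter of each other: a 1.1-fold higher number from compound 1 to compound 2 (0.06 log units; within the scatter). Compound 3 `CCCCCCCCCCCCCCCCCCNC(=O)[C@@H](NC(=O)c1cc2ccccc2o1)[C@@H](C)O` carries a longer chain, the difference from compound 1 being (butyl in place of hydrogen on a saturated chain carbon, ten or more bonds along the chain from an amide-type nitrogen), and in this assay compound 3 gives 78800 nM; the step of a 3.9-fold higher number from compound 1 to compound 3 (0.59 log units; beyond the scatter).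

Compound 4 `CCCCCCCCCCCCCCCCCCNC(=O)[C@@H](NC(=O)c1nccc2ccccc12)[C@@H](C)O` is not yet measured in this assay. It differs from compound 3 by isoquinolin-1-yl in place of 1-benzofuran-2-yl on a carbonyl carbon, the same change made between compound 1 and compound 2, set on the same place. The cores of compound 3 and compound 4 differ from those of compound 1 and compound 2 only by the chain change described above.

Since the earlier instance of this change left the number within the scatter, the step from compound 3 to compound 4 is expected to be about as small, a 1.1-fold higher number from compound 3 to compound 4 (0.03 log units; within the scatter), resting on a 1.1-fold higher number from compound 1 to compound 2 (0.06 log units; within the scatter). Compound 4 is therefore estimated at 85000 nM in this assay, between 40000 nM and 180000 nM.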

Compound 4, half-maximal inhibitory concentration: 44100 nM
Beside the measured number, compound 4's estimate is 1.9-fold (0.28 log units) above it; the range from low to high includes it.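

In this assay, isoquinolin-1-yl in place of 1-benzofuran-2-yl gives a 1.8-fold lower number from compound 3 to compound 4 (0.25 log units; within the scatter), and this step agrees with the earlier instance of the same change: the same change on two cores in this assay, a 1.1-fold higher number (0.06 log units; within the scatter) from compound 1 to compound 2 and a 1.8-fold lower number (0.25 log units; within the scatter) from compound 3 to compound 4, 2.0-fold (0.31 log units) apart, within the scatter of two such steps. The butyl extension of the chain gives a 1.9-fold higher number from compound 2 to compound 4 (0.28 log units; within the scatter) on the isoquinolin-1-yl side, and this step also cannot be told apart from its counterpart on the 1-benzofuran-2-yl side: the same change on two cores in this assay, a 3.9-fold higher number (0.59 log units; beyond the scatter) from compound 1 to compound 3 and a 1.9-fold higher number (0.28 log units; within the scatter) from compound 2 to compound 4, 2.0-fold (0.31 log units) apart, within the scatter of two such steps. The ring exchange therefore carries from the core of compound 1 to the core of compound 3 with no step beyond the scatter, but two pairs on two chain lengths do not show that it would carry to other cores, nor do they establish a real difference in the sizes of the two chain steps.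

The compounds shown leave open whether the same agreement would hold with a shorter chain, or with an amine in place of the hydroxyl group. They also leave open how a carboxylic acid on the aromatic ring of the acyl group would behave in this series.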